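The source may hold more compounds than are shown below. What is called first, only, known or untested is meant among the compounds shown, and "the series" means these compounds.

Measured compounds in a functional assay on SW-620 cells (Homo sapiens) for inhibition, read by sulforhodamine B assay, with a stated time of 48 h, tested at 0.01 uM; a higher number here means a weaker effect of the compound at the concentration tested, a lower number a stronger effect:
compound 1 `O=C(Nc1cccc(-n2cc(-c3ccncc3)c(-c3cc(O)cc(Cl)c3)n2)c1)Nc1ccc(Cl)c(C(F)(F)F)c1`, 97%
compound 2 `O=C(Nc1cccc(-n2cc(-c3ccncc3)c(-c3cc(O)cc(Cl)c3)n2)c1)Nc1ccc(Cl)c(Cl)c1`, 96%
compound 3 `COc1cc(Cl)cc(-c2nn(-c3cccc(NC(=O)Nc4cc(C(F)(F)F)cc(C(F)(F)F)c4)c3)cc2-c2ccncc2)c1`, 98%

Compound 3 gives the highest of the three numbers, but its gaps to compound 1 and to compound 2 both lie within the usual scatter, so the three stand level. Compound 4 `COc1cc(Cl)cc(-c2nn(-c3cccc(NC(=O)Nc4cccc(C(F)(F)F)c4)c3)cc2-c2ccncc2)c1` is not yet measured; it differs from compound 3 by hydrogen in place of trifluoromethyl on an aromatic carbon. Going by the values given here, the one measured step that bears on this change is a number 1 percentage points lower from compound 1 to compound 2 (within the scatter), which swapped one group for another on an aromatic carbon without moving the number beyond the scatter. Compound 4 is therefore expected to stay close to compound 3, the expected step being a number 3 percentage points lower from compound 3 to compound 4 (within the scatter). The estimate for compound 4 in this assay is 95%, between 85% and 100%.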

Compound 4, a percentage reported as activity, at one concentration (the size of the read-out at that concentration, not a potency): 103%
Beside the measured number, compound 4's estimate is 8 percentage points below it, outside the stated range (above it).
By their numbers in this assay, from the lowest: compounds 2, 1, 3 and 4 (each within the scatter of the next).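

In this assay the change gives a number 5 percentage points higher from compound 3 to compound 4 (within the scatter). The earlier step only swapped one group for another on an aromatic carbon, whereas this one removes the trifluoromethyl group altogether, leaving hydrogen, and the number still does not move beyond the scatter. Nothing measured here explains this result. Still open, from the compounds shown here alone, is whether a group of another kind on this carbon, such as an amine or a carboxylic acid, would give a number beyond the scatter from compound 4.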